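Lengthening the Ester Chain: What Compound 3 May Show

This account rests on a few compounds, and the source may have more. Where it says the series, first, only, none or still open, it means among the compounds named here.

In a functional assay on A549 cells (Homo sapiens) for cytotoxicity, read by MTT assay, with a stated time of 24 h, tested at 20 uM (a lower number here means a stronger effect, a higher number a weaker effect of the compound at the concentration tested), compound 1 `CCCCCOC(=O)CCC(=O)N1CCN(CCCOc2cc3c(Nc4ccc(F)c(Cl)c4)ncnc3cc2OC)CC1` gives 81.2%, and compound 2 `CCCCCCCCCCCCCOC(=O)CCC(=O)N1CCN(CCCOc2cc3c(Nc4ccc(F)c(Cl)c4)ncnc3cc2OC)CC1` gives 93.8%, the higher of the two numbers, reached by the step of a number 12.6 percentage points higher from compound 1 to compound 2 (beyond the scatter). Compound 3 `CCCCCCCCCCCCCCCCCOC(=O)CCC(=O)N1CCN(CCCOc2cc3c(Nc4ccc(F)c(Cl)c4)ncnc3cc2OC)CC1` differs from compound 2 by butyl in place of hydrogen on a saturated chain carbon, ten or more bonds along the chain from an oxygen next to a carbonyl group. Among the measured compounds shown here, only that one measured step bears on this change, and it was modest. The change now is smaller and sits farther out along the chain, so the step expected is a number 3.2 percentage points higher from compound 2 to compound 3 (within the scatter), a rise that hardly clears the scatter. Compound 3 is therefore estimated at 97%, within a range from 87% to 105%.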

Compound 3, a percentage reported as activity, at one concentration (the size of the read-out at that concentration, not a potency): 97.2%
Beside the measured number, compound 3's estimate is 0.2 percentage points below it; measured number inside the range.
By their numbers in this assay, from the lowest: compound 1; then compounds 2 and 3 (each within the scatter of the next).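

In this assay, butyl in place of hydrogen on a saturated chain carbon gives a number 3.4 percentage points higher from compound 2 to compound 3 (within the scatter), so this further lengthening cannot be told apart from repeat-measurement noise. The full change, dodecyl in place of hydrogen, gives a number 16 percentage points higher from compound 1 to compound 3 (beyond the scatter), which keeps compound 3 clearly apart from compound 1. Nothing measured here says why the numbers fall this way. Going by these compounds, what stays open is whether a chain shorter than that of compound 1, or a chain ending in an amine or a carboxylic acid, would give a lower number.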